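From a urea to a benzamide on a shared core

This account rests on a few compounds, and the source may have more. Where it says the series, first, only, none or still open, it means among the compounds named here.

Compound 2 `CCCNC(=O)Nc1n[nH]c2c1CN(C(=O)C1CCN(C)CC1)C2(C)C` and compound 1 `CN1CCC(C(=O)N2Cc3c(NC(=O)c4ccsc4)n[nH]c3C2(C)C)CC1` share one core and differ only at a carbonyl carbon. In a physicochemical assay for solubility, at pH 7 (on this read-out higher numbers stand for higher solubility and lower numbers for lower solubility), compound 1 reaches a limit of the assay, > 225000 nM. In this assay compound 2 also reaches a limit, > 225000 nM. The step that the two limits leave unreadable from compound 1 to compound 2 therefore cannot be sized, and compound 2 stands at a limit rather than at a number. Compound 3 `CN1CCC(C(=O)N2Cc3c(NC(=O)c4ccccc4)n[nH]c3C2(C)C)CC1` is the next member: phenyl in place of propylamino on a carbonyl carbon. For the measured compounds named here, the only measured step bears on this change but gives no size, because the limit of > 225000 nM in this assay, at which 2 of the 2 values shown sit, places both values at that limit. Neither change at the carbonyl carbon has yet pulled a compound out of the limit region, so no step beyond the scatter is read from the data. Compound 3 is therefore expected to sit near that limit, at about 200000 nM, between 60000 nM and 300000 nM. The expected step of an at least 1.1-fold lower number from compound 2 to compound 3 (0.05 log units; that floor lies within the scatter) is thus small.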

Compound 3, solubility: > 225000 nM
Compound 3: a limit, no number; the forecaster's own chance of this, stated with the estimate: 60%; middle value at least 1.1-fold (0.05 log units) from the limit.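

In this assay compound 3 gives > 225000 nM as a limit of the assay, not a number. For the compounds shown here, no step among compound 1, compound 2 and compound 3 can be read: the limit of > 225000 nM in this assay, at which 3 of the 3 values shown sit. The compounds shown leave open how far apart these three truly lie.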